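Replacing oxan-4-yl with 4-cyanophenyl: expected solubility

The source may hold more compounds than are shown below. What is called first, only, known or untested is meant among the compounds shown, and "the series" means these compounds.

Measured compounds:
- compound 1 `Cc1noc(-c2nc(C)c3c(c2N)C(=O)N(CC2CCOCC2)C3=O)n1`: 5700 nM
- compound 2 `Cc1noc(-c2nc(C)c3c(c2N)C(=O)N(Cc2ccc(Cl)cn2)C3=O)n1`: < 5000 nM
- compound 3 `Cc1noc(-c2nc(C)c3c(c2N)C(=O)N(Cc2ccncc2)C3=O)n1`: 26400 nM

In a physicochemical assay for solubility, using the shake flask method, in simulated intestinal fluid, measured as kinetic solubility, with a stated time of 2 h, at 25 degrees C, at pH 6.5 (on this read-out higher numbers stand for higher solubility and lower numbers for lower solubility), compound 1 gives 5700 nM, the lowest of the two numbers available. Compound 3 gives 26400 nM in this assay, and the step of a 4.6-fold higher number from compound 1 to compound 3 (0.67 log units; beyond the scatter) is clear. Compound 2 gives only a limit in this assay, < 5000 nM, so its step from compound 1, an at least 1.1-fold lower number from compound 1 to compound 2 (0.05 log units; that floor lies within the scatter), is known only as a floor (the limit of < 5000 nM in this assay, at which 1 of the 3 values shown sits).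

Compound 4 `Cc1noc(-c2nc(C)c3c(c2N)C(=O)N(Cc2ccc(C#N)cc2)C3=O)n1` has not been measured. It differs from compound 1 by 4-cyanophenyl in place of oxan-4-yl on a saturated chain carbon bound to an amide-type nitrogen in a ring. Within the data shown here, of the measured steps, the one from compound 1 to compound 2 is the closest comparison, since both replace oxan-4-yl with an aromatic ring that lacks the pyridin-4-yl of compound 3. Among the measured compounds shown here, that step pointed downward, and the one to compound 3 pointed upward. Compound 4 is therefore expected to give a somewhat lower number than compound 1, an estimated step of a 1.6-fold lower number from compound 1 to compound 4 (0.21 log units; within the scatter), with an estimated value of 3500 nM and a range from 1200 nM to 11000 nM.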

Compound 4, solubility: < 5000 nM
Compound 4 ended at the assay's limit; the forecaster's own chance of this, stated with the estimate: 50%; the middle value is on the limit's open side.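

In this assay, the 4-cyanophenyl group on this saturated chain carbon gives an at least 5.2-fold lower number from compound 3 to compound 4 (0.72 log units; beyond the scatter), so the high number seen with pyridin-4-yl does not carry over to every aromatic ring here. Against oxan-4-yl, the change gives an at least 1.1-fold lower number from compound 1 to compound 4 (0.05 log units; that floor lies within the scatter), which leaves no firm order between those two groups. The value of compound 4 is a limit and not a number, and compound 4 joins compound 2 there, leaving pyridin-4-yl as the only aromatic group shown that stands clear of it: the limit of < 5000 nM in this assay, at which 2 of the 4 values shown sit.

Both compound 2 and compound 4 give limits, so the step between them cannot be read. As far as these compounds go, it remains open whether a pyridin-3-yl or piperidin-4-yl group at this place would stay near compound 3 or also end at the limit.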